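The source may hold more compounds than are shown below. What is called first, only, known or untested is meant among the compounds shown, and "the series" means these compounds.

Compound 3 `CCOc1ccc(-c2cccc(S(=O)(=O)NC)c2)cc1` bears a methylsulfamoyl group on its core, and in an assay on COS-7 cells for inhibition of patatin-like phospholipase domain-containing protein 2 (Mus musculus) (on this read-out higher numbers stand for weaker inhibition and lower numbers for stronger inhibition), compound 3 gives 200000 nM. Compound 2 `CCOC(=O)c1cccc(-c2ccc(CN(C)C)o2)c1`, a compound of different make-up, gives 190000 nM in this assay, and the two numbers sit within the scatter of each other, so neither can be set above the other. For compound 1 `CCOC(=O)c1cccc(-c2ccncc2)c1` the outcome in this assay is a limit rather than a number, > 200000 nM, as described by the limit of > 200000 nM in this assay, at which 1 of the 3 values shown sits. Compound 4 `CCOc1ccc(-c2cccc(C(=O)N3CCCC3)c2)cc1` has not yet been measured. It differs from compound 3 in one place: (pyrrolidin-1-yl)carbonyl in place of methylsulfamoyl on an aromatic carbon. No step between measured compounds bears on this change, and all numbers shown are weak, so the expectation can only rest on that weakness. The step of a 1.3-fold lower number from compound 3 to compound 4 (0.12 log units; within the scatter) is expected to fall within the scatter, in no direction beyond it. Compound 4 is therefore estimated at 150000 nM in this assay, with a range from 40000 nM to 600000 nM.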

Compound 4, half-maximal inhibitory concentration: 160000 nM
For compound 4 the middle estimate is 1.1-fold (0.03 log units) below the measured one; the measured number falls inside the stated range.
By their numbers in this assay, from the lowest: compounds 4, 2 and 3 (each within the scatter of the next).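

In this assay, going by these compounds alone, this is the first change in one place that can be read, and it gives a 1.3-fold lower number from compound 3 to compound 4 (0.10 log units; within the scatter). On this aromatic carbon, methylsulfamoyl, with its hydrogen-bond donor, and (pyrrolidin-1-yl)carbonyl, with no donor and a five-membered non-aromatic ring, therefore cannot be told apart, although the entering group is the larger by heavy-atom count. Compound 1 remains a limit and not a number, so it cannot be placed in this comparison: the limit of > 200000 nM in this assay, at which 1 of the 4 values shown sits.

Going by these compounds, whether any group on this aromatic carbon can move the number beyond the scatter remains open, and a carboxylic acid or an amine there would test this. On these data alone, it is equally open whether a longer chain on the nitrogen of the amide would read differently from the pyrrolidine ring.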